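Aryl variation on the imine carbon of the shared core

This account rests on a few compounds, and the source may have more. Where it says the series, first, only, none or still open, it means among the compounds named here.

Going by the values given here, compound 2 `Oc1ccccc1/C=N/c1nnc(SCc2c[se]c(-c3ccccc3)n2)s1` gives 15200 nM in a functional assay on MCF7 cells (Homo sapiens) for antiproliferative activity, read by CCK-8 assay (a higher number here means a weaker inhibitor, a lower number a stronger inhibitor), the higher of the two numbers measured so far, but the gap to compound 1 `Fc1ccc(/C=N/c2nnc(SCc3c[se]c(-c4ccccc4)n3)s2)cc1`, which gives 10200 nM, is within the scatter: a 1.5-fold higher number from compound 1 to compound 2 (0.17 log units; within the scatter). Compound 3 `CN(C)c1ccc(/C=N/c2nnc(SCc3c[se]c(-c4ccccc4)n3)s2)cc1` carries 4-(dimethylamino)phenyl in place of 2-hydroxyphenyl on a carbon with a double bond to nitrogen. Among the compounds with values here, the only measured step that bears on this aryl exchange on the imine carbon is that from compound 1 to compound 2, and it stayed within the scatter, so for compound 3 no step beyond the scatter is expected: a 1.3-fold lower number from compound 2 to compound 3 (0.10 log units; within the scatter). The estimate for compound 3 in this assay is 12000 nM, range 4000 nM to 40000 nM.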

Compound 3, half-maximal inhibitory concentration: 80300 nM
Compound 3: middle estimate off by 6.7-fold (0.83 log units), on the low side, and the stated range ends below it.
By their numbers in this assay, from the lowest: compounds 1 and 2 (each within the scatter of the next); then compound 3.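

In this assay, going by these compounds alone, the aryl group on the carbon with a double bond to nitrogen proves not to be freely exchangeable: 4-(dimethylamino)phenyl in place of 2-hydroxyphenyl gives a 5.3-fold higher number from compound 2 to compound 3 (0.72 log units; beyond the scatter), the first step at this position beyond the scatter. Dimethylamino in place of fluoro on an aromatic carbon gives a 7.9-fold higher number from compound 1 to compound 3 (0.90 log units; beyond the scatter), leaving compound 3 the weakest of the three. Nothing measured here accounts for these steps. From the compounds shown here alone, whether a primary amine or a methoxy group on that phenyl ring would track dimethylamino or fluoro remains open.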